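The source may report more compounds than this note shows. Statements on the series, on what has been measured and on what is new or still open speak of the compounds shown alone.

Compounds measured so far, with their results in an assay on cells for displacement of a labelled ligand from Neuronal acetylcholine receptor; alpha3/beta4 (Homo sapiens); on this read-out higher numbers stand for weaker inhibition and lower numbers for stronger inhibition:

Compound 1, `O=C(Nc1ccc(F)cc1)c1cncc(N2CC3CC(C2)N3)c1`: 81 nM
Compound 2, `O=C(c1cncc(N2CC3CC(C2)N3)c1)N1CCCc2ccccc21`: 62 nM
Compound 3, `O=C(c1cncc(N2CC3CC(C2)N3)c1)N1CCc2ccccc2C1`: 21 nM

All three share the same core, and they differ only in the group carried on the amide. On this read-out compound 1 stands at the highest number of the three. Compound 2 sits close by, and the gap between compound 1 and compound 2 lies within the usual scatter of this assay, so the two cannot be told apart. Compound 3 lies further off at a lower number, and that gap is beyond the scatter, so compound 3 is the one clearly stronger inhibitor among the three.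

Compound 4, `O=C(Nc1cccc(Cl)c1)c1cncc(N2CC3CC(C2)N3)c1`, has not yet been measured. It keeps the amide of compound 1 and changes only the ring on it: 3-chlorophenyl in place of 4-fluorophenyl on an amide-type nitrogen. Within the data shown here, no measured pair shows the effect of such a swap, so the expectation rests on the change being a small one in a region where compound 1 and compound 2 already look alike. The step from compound 1 is expected to be small, most likely within the scatter, with no clear direction: a 1.2-fold lower number from compound 1 to compound 4 (0.06 log units; within the scatter). Compound 4 is therefore estimated at 70 nM, with a likely range from 25 nM to 200 nM.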

Compound 4, inhibition constant: 59 nM
For compound 4 the middle estimate is 1.2-fold (0.07 log units) above the measured one; the range from low to high includes it.
By their numbers in this assay, from the lowest: compound 3; then compounds 4, 2 and 1 (each within the scatter of the next).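

In this assay, 3-chlorophenyl in place of 4-fluorophenyl on the amide-type nitrogen gives a 1.4-fold lower number from compound 1 to compound 4 (0.14 log units; within the scatter), the first pair shown that differs in one place only. The two compounds cannot be told apart, so at this position one halogen-bearing phenyl ring can stand in for the other with no clear effect on the read-out, although the swap alters both the halogen and where it sits, and the two alterations cannot be separated here. Nothing available explains why these two compounds read alike.

A 3-fluorophenyl or 4-chlorophenyl group would show what the halogen and its place each contribute. From the compounds shown here alone, it also remains open how the read-out responds to a phenyl ring carrying an amine or a carboxylic acid instead of a halogen.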